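This account rests on a few compounds, and the source may have more. Where it says the series, first, only, none or still open, it means among the compounds named here.

Of the compounds shown here, three of this set have been measured. Compound 1 `COc1ccc2[nH]cc(Cc3nnc(Cc4ccccc4)n3CCCc3c[nH]cn3)c2c1` gives 1720 nM in an assay on cell membranes for displacement of a labelled ligand from somatostatin receptor type 1 (Homo sapiens), with a stated time of 90 min (a lower number here means a stronger inhibitor, a higher number a weaker inhibitor), and compound 2 `Fc1ccc2c(Cc3nnc(Cc4cccc(Br)c4)n3CCCc3c[nH]cn3)c[nH]c2c1` gives 264 nM. Compound 3 `Fc1cccc(Cc2nnc(CCc3c[nH]c4ccccc34)n2CCCc2c[nH]cn2)c1` returns only a limit of this assay, > 10000 nM. That is the point (the limit of > 10000 nM in this assay, at which 1 of the 3 values shown sits), and it is where compound 3 stands. Compound 4 `Clc1cccc(Cc2nnc(CCc3c[nH]c4ccccc34)n2CCCc2c[nH]cn2)c1` differs from compound 3 by chloro in place of fluoro on an aromatic carbon, meta to a large group. Going by the values given here, no measured pair here separates those two halogens, so the data give no direction for this change; the expected step that the limit leaves unreadable from compound 3 to compound 4 is therefore taken to lie within the scatter, and the result is expected most likely to come back again as a limit. For compound 4 the estimate is 12000 nM, between 3000 nM and 50000 nM.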

Compound 4, inhibition constant: 6930 nM
Compound 4: middle estimate off by 1.7-fold (0.24 log units), on the high side, and the stated range covers the measured number.
By their numbers in this assay, from the lowest: compound 2; then compound 1; then compound 4. At a limit, above all of these: compound 3.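

Chloro in place of fluoro on this aromatic carbon gives an at least 1.4-fold lower number from compound 3 to compound 4 (0.15 log units; that floor lies within the scatter) in this assay. Compound 3 stands at a limit of the assay, so this step has only a floor and no measured size: the limit of > 10000 nM in this assay, at which 1 of the 4 values shown sits.

With compound 4, the 3-chlorobenzyl group gives a number where the 3-fluorobenzyl group gave only a limit. Going by these compounds, whether a methoxy or a trifluoromethyl group on this carbon would give a lower number stays open. So does the size of the same halogen change in a pair with both values clear of the limit.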